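Ester to acid on two cores in a cytotoxicity screen

The source may hold more compounds than are shown below. What is called first, only, known or untested is meant among the compounds shown, and "the series" means these compounds.

Compound 1, `CCOC(=O)c1ccc(SCc2ccc3nc(OC)c(OC)nc3c2)cc1`, compound 2, `COc1nc2ccc(CSc3ccc(C(=O)O)cc3)cc2nc1OC`, and compound 3, `CCOC(=O)c1ccc(SCc2ccc3nc(OC)c(OC)nc3c2)nc1`, were measured in an ADME assay on Vero 76 cells (Chlorocebus sabaeus) for cytotoxicity, read by MTT assay, with a stated time of 96 h; a lower number here means that less compound is tolerated, a higher number that more compound is tolerated. Compound 1 sits at the limit of this assay, giving > 100000 nM. Compound 2 gives 65000 nM in this assay. Compound 3 also sits at the limit of this assay, with > 100000 nM. The difference between the core of compound 1 and the core of compound 3 is not broken down here.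

Compound 2 differs from compound 1 by one change: hydrogen in place of ethyl on an oxygen next to a carbonyl group. That change produced an at least 1.5-fold lower number from compound 1 to compound 2 (0.18 log units; that floor lies within the scatter). Its size is bounded only at one end because of the limit of > 100000 nM in this assay, at which 2 of the 3 values shown sit.

Compound 4, `COc1nc2ccc(CSc3ccc(C(=O)O)cn3)cc2nc1OC`, has not yet been measured. It differs from compound 3 by the same change, (hydrogen in place of ethyl on an oxygen next to a carbonyl group), made on the core of compound 3 instead of the core of compound 1.

The step in this assay from compound 3 to compound 4 is expected to be about an at least 1.4-fold lower number from compound 3 to compound 4 (0.15 log units; that floor lies within the scatter), resting on the step from compound 1 to compound 2, an at least 1.5-fold lower number from compound 1 to compound 2 (0.18 log units; that floor lies within the scatter), since compound 3 starts from the same limit as compound 1 did. The value of compound 4 in this assay is estimated at 70000 nM, with a plausible range from 30000 nM to 150000 nM; a result again reported only as a limit would not be surprising.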

Compound 4, half-maximal cytotoxic concentration: 90000 nM
Beside the measured number, compound 4's estimate is 1.3-fold (0.11 log units) below it, and the stated range covers the measured number.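

In this assay, the change from ethoxycarbonyl to carboxy on the core of compound 3 gave an at least 1.1-fold lower number from compound 3 to compound 4 (0.04 log units; that floor lies within the scatter). On both cores the ethyl ester stands at a limit of the assay and the acid gives a measured number, so the pattern holds for these two pairs, but neither step has a fixed size, and the comparison reads: the same change on two cores in this assay, an at least 1.5-fold lower number (0.18 log units; that floor lies within the scatter) from compound 1 to compound 2 and an at least 1.1-fold lower number (0.04 log units; that floor lies within the scatter) from compound 3 to compound 4; the limit leaves it open whether they differ. The data therefore do not show whether the change has the same size on the two cores, or whether either step goes beyond the scatter, and the esters offer no true starting value: the limit of > 100000 nM in this assay, at which 2 of the 4 values shown sit.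

The compounds shown carry only the ethyl ester and the carboxylic acid at this place, so it remains open how a primary amide, a methyl ester or a primary alcohol there would read in this assay. On these data alone, it also remains open whether an ester with a longer chain would give a measured number rather than a limit, which would allow the size of the step to be read on either core.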